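Open-chain amines replacing the carboxypiperidine on the benzyl carbon

The compounds below may be only part of what the source reports. "The series", "measured", "known", "first", "only" and "open" are said of these compounds alone.

Measured so far in a functional assay on HepG2 cells (Homo sapiens) for antiproliferative activity, read by CCK-8 assay, with a stated time of 48 h; a lower number here means a stronger inhibitor, a higher number a weaker inhibitor:
compound 1 `COc1ccc(/C=C\c2cc(OC)c(OC)c(OC)c2)cc1OCc1ccc(CN2CCCC[C@@H]2C(=O)O)cc1`: > 10000 nM
compound 2 `COc1ccc(/C=C\c2cc(OC)c(OC)c(OC)c2)cc1OCc1ccc(CNCCO)cc1`: 5900 nM
compound 3 `COc1ccc(/C=C\c2cc(OC)c(OC)c(OC)c2)cc1OCc1ccc(CN2CCCCC2C(=O)NCCNC(=O)OC(C)(C)C)cc1`: 1100 nM.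

For compound 1 the value in this assay is a limit of the assay and not a number, (the limit of > 10000 nM in this assay, at which 1 of the 3 values shown sits). Compound 4 `COc1ccc(/C=C\c2cc(OC)c(OC)c(OC)c2)cc1OCc1ccc(CNCCNC(C)=O)cc1` is not yet measured; it differs from compound 1 by (2-acetamidoethyl)amino in place of 2-carboxypiperidin-1-yl on a saturated chain carbon bound to an aromatic carbon. Among the compounds with values here, the one measured step that bears on it is an at least 1.6-fold lower number from compound 1 to compound 2 (0.22 log units; that floor lies within the scatter), where likewise an open-chain amine replaces the 2-carboxypiperidin-1-yl group. Compound 3, which keeps the piperidine ring, gives 1100 nM in this assay. A step of similar size toward a lower number is therefore expected, estimated as an at least 2.2-fold lower number from compound 1 to compound 4 (0.34 log units; beyond the scatter). Compound 4 is expected at 4500 nM, within 1500 nM to 15000 nM.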

Compound 4, half-maximal inhibitory concentration: 6100 nM
For compound 4 the middle estimate is 1.4-fold (0.13 log units) below the measured one; measured number inside the range.
By their numbers in this assay, from the lowest: compound 3; then compounds 2 and 4 (each within the scatter of the next). At a limit, above all of these: compound 1.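

In this assay, acetamido in place of hydroxy on the open chain gives a 1.0-fold higher number from compound 2 to compound 4 (0.01 log units; within the scatter), so these two chain ends cannot be told apart. The replacement of the ring gives an at least 1.6-fold lower number from compound 1 to compound 4 (0.21 log units; that floor lies within the scatter), and this floor alone does not establish a gain from either open-chain amine. Compound 1 stands at a limit of the assay and not at a number: the limit of > 10000 nM in this assay, at which 1 of the 4 values shown sits.

From the compounds shown here alone, how far compound 1 truly lies from compound 4 remains open. Also open, going by these compounds, is whether a primary amine, a carboxylic acid or a longer chain at this chain end would separate from hydroxy and acetamido.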